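Linker variation on the shared core: toward compound 4

A few compounds are considered here, and "the series" means these few. Any claim that something is new, unique, unknown or untested is made for them only; others in the source may bear on it.

Measured so far in an assay for inhibition of Thromboxane-A synthase (Homo sapiens), using microsomes; a lower number here means a stronger inhibitor, a higher number a weaker inhibitor:
- compound 1 `CC(C)(Oc1ccc(F)cc1)C1OCC(C/C=C\CCC(=O)O)C(c2cccnc2)O1` gives 51 nM
- compound 2 `CC(C)(Oc1ccccc1[N+](=O)[O-])C1OCC(C/C=C\CCC(=O)O)C(c2cccnc2)O1` gives < 10 nM; this value is a limit of this assay, not a number
- compound 3 `CC(C)(C1OCC(C/C=C\CCC(=O)O)C(c2cccnc2)O1)S(=O)(=O)c1ccccc1` gives 40 nM

Compound 3 and compound 1 sit within the scatter of each other; a 1.3-fold lower number from compound 1 to compound 3 (0.11 log units; within the scatter). Compound 2 reaches the limit noted in the limit of < 10 nM in this assay, at which 1 of the 3 values shown sits, and an at least 4.0-fold higher number from compound 2 to compound 3 (0.60 log units; beyond the scatter).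

Compound 4 `CC(C)(Cc1ccc(F)cc1)C1OCC(C/C=C\CCC(=O)O)C(c2cccnc2)O1` is not yet measured. It differs from compound 3 in one place: 4-fluorobenzyl in place of phenylsulfonyl on a saturated chain carbon bound to two saturated chain carbons and a saturated ring carbon. Of the measured steps, only the swap from compound 1 to compound 3 involves the phenylsulfonyl at this place, and that step lay within the scatter. Going by the values given here, no measured step exchanges an oxygen-linked aryl for a benzyl, so the new change has no direct precedent. A return toward the 4-fluorophenyl-bearing region of compound 1 is expected to leave this assay roughly unchanged: a 1.5-fold higher number from compound 3 to compound 4 (0.18 log units; within the scatter) is expected to stay within the scatter. Compound 4 is therefore estimated at 60 nM, with a range from 20 nM to 180 nM.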

Compound 4, half-maximal inhibitory concentration: 45 nM
For compound 4 the middle estimate is 1.3-fold (0.12 log units) above the measured one; low and high end bracket the measured number.
By their numbers in this assay, from the lowest: compounds 3, 4 and 1 (each within the scatter of the next). At a limit, below all of these: compound 2.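

At this place, on the saturated chain carbon, the link to the aryl ring can be a methylene rather than an oxygen or a sulfonyl with no shift outside the scatter in this assay, with a 1.1-fold lower number from compound 1 to compound 4 (0.05 log units; within the scatter) and a 1.1-fold higher number from compound 3 to compound 4 (0.05 log units; within the scatter) as the two readings. The 2-nitrophenoxy group remains apart, at an at least 4.5-fold higher number from compound 2 to compound 4 (0.65 log units; beyond the scatter) as the gap to the benzyl. The value of compound 2 is a limit, not a number: the limit of < 10 nM in this assay, at which 1 of the 4 values shown sits.

Still open, as far as these compounds go, is whether 2-nitrobenzyl would read like compound 2 or like compound 4. Also open, from the compounds shown here alone, is how an amine or a carboxylic acid on this aryl ring would read.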